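Changing one group on the shared core

The source may hold more compounds than are shown below. What is called first, only, known or untested is meant among the compounds shown, and "the series" means these compounds.

In a functional assay (blood) for inhibition, with Homo sapiens as the target (a lower number here means a stronger inhibitor, a higher number a weaker inhibitor), compound 3 `OC1(c2cccc(COc3ccc4c(-c5ccoc5)cc(C5=NCCO5)cc4c3)c2)CCOCC1` gives 50 nM and compound 1 `CC(=O)c1cc(-c2ccccc2)c2ccc(OCc3cccc(C4(O)CCOCC4)c3)cc2c1` gives 90 nM, so the two sit within the scatter of each other. Compound 2 `OC1(c2cccc(COc3ccc4c(-c5ccccc5)cc(-c5nn[nH]n5)cc4c3)c2)CCOCC1` gives > 3000 nM, which is a limit of the assay and not a number.

Compound 4 `OC1(c2cccc(COc3ccc4c(-c5ccoc5)cc(Cc5nccs5)cc4c3)c2)CCOCC1` differs from compound 3 in one place, on an aromatic carbon meta to a furan-3-yl group: a group of 6 heavy atoms (4 carbon, 1 nitrogen, 1 sulfur; one five-membered aromatic ring with 2 hetero atoms) in place of a group of 5 heavy atoms (3 carbon, 1 nitrogen, 1 oxygen; one five-membered non-aromatic ring with 2 hetero atoms), on an aromatic carbon.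

Within the data shown here, one measured step bears on this place. Putting 2H-tetrazol-5-yl in place of acetyl gave an at least 33-fold higher number from compound 1 to compound 2 (1.52 log units; beyond the scatter), a large step beyond the scatter. That group does not enter here, so this step sets no size for the new change. The (1,3-thiazol-2-yl)methyl group carries no net charge, like the group it replaces, and compound 1 and compound 3 show that two different groups at this carbon can give values within the scatter, although these two compounds also differ elsewhere.

In this assay no step beyond the scatter is expected, and the estimated step is a 1.8-fold higher number from compound 3 to compound 4 (0.26 log units; within the scatter). For compound 4 the estimated value is 90 nM, with an expected range of 30 nM to 300 nM.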

Compound 4, half-maximal inhibitory concentration: 660 nM
Compound 4: middle estimate off by 7.3-fold (0.87 log units), on the low side; measured number outside the range, above it.
By their numbers in this assay, from the lowest: compounds 3 and 1 (each within the scatter of the next); then compound 4. At a limit, above all of these: compound 2.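

In this assay, replacing the five-membered non-aromatic ring group with (1,3-thiazol-2-yl)methyl on this aromatic carbon gave a 13-fold higher number from compound 3 to compound 4 (1.12 log units; beyond the scatter), a large step. Among these compounds, the only earlier step at this carbon took acetyl to 2H-tetrazol-5-yl, whereas here both groups carry no net charge and have the same counts of hydrogen-bond donors and acceptors, so matching these features does not keep the value in place. The data shown give no cause for this step.

The compounds shown do not separate the contribution of the thiazole ring from that of its one-carbon link, a question that a directly attached 1,3-thiazol-2-yl group or a benzyl group would address. As far as these compounds go, how an amine or a carboxylic acid at this carbon would behave alongside the furan-3-yl group also remains open.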